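A few compounds are considered here, and "the series" means these few. Any claim that something is new, unique, unknown or untested is made for them only; others in the source may bear on it.

Compound 1 `C=C1CC[C@H]2[C@@](C)(CC[C@@H](OC(C)=O)[C@@]2(C)C(=O)OCc2ccccn2)[C@@H]1CCC1=CCOC1=O` gives 55500 nM in a functional assay on NIH3T3 cells (Mus musculus) for inhibition, read by MTT assay, with a stated time of 72 h; a lower number here means a stronger inhibitor, a higher number a weaker inhibitor. Among the measured compounds shown here, compound 2 `C=C1CC[C@H]2[C@@](C)(CC[C@@H](OC(C)=O)[C@@]2(C)C(=O)OCc2ccccn2)[C@@H]1/C=C/C1=CCOC1=O` gives 34900 nM in this assay, the single measured step being a 1.6-fold lower number from compound 1 to compound 2 (0.20 log units; within the scatter). Compound 2 thus holds the lower of the two numbers, with compound 1 within the scatter of it. Compound 3 `C=C1CC[C@H]2[C@@](C)(CC[C@@H](O)[C@@]2(C)C(=O)OCc2ccccn2)[C@@H]1/C=C/C1=CCOC1=O` differs from compound 2 by hydrogen in place of acetyl on an oxygen on a saturated carbon. For the measured compounds named here, no measured step touches this oxygen. Going by the values given here, the only step in hand changes a group on a saturated ring carbon and stays within the scatter, so it offers no guidance. For compound 3 no step beyond the scatter is expected, the estimated step being a 1.0-fold higher number from compound 2 to compound 3 (0.00 log units; within the scatter). Compound 3 is expected near 35000 nM, within 12000 nM to 100000 nM.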

Compound 3, half-maximal inhibitory concentration: 80200 nM
The estimate for compound 3 lay 2.3-fold (0.36 log units) below the measured number, and the stated range covers the measured number.
By their numbers in this assay, from the lowest: compounds 2, 1 and 3 (each within the scatter of the next, the first and the last beyond it).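

In this assay, acetoxy to hydroxy on the oxygen on a saturated carbon gives a 2.3-fold higher number from compound 2 to compound 3 (0.36 log units; beyond the scatter), the only step shown that lies beyond the scatter, though a modest one. This position therefore responds to the change, with the acetyl-bearing compound holding the lower number, though this rests on a single pair. Nothing available explains this shift.

Going by these compounds, whether a benzoyl ester, a methyl ether or an amine here would move the number further remains open. So does whether the same step holds on the core of compound 1.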